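Swapping a Pyridyl for a Dimethoxyphenyl on the Piperazine

This account rests on a few compounds, and the source may have more. Where it says the series, first, only, none or still open, it means among the compounds named here.

Of the compounds shown here, three built on a shared core have been measured in a functional assay for antagonist activity at Alpha-1A adrenergic receptor (Oryctolagus cuniculus); on this read-out higher numbers stand for weaker binding and lower numbers for tighter binding. Compound 1 `COc1ccccc1N1CCN(CCCNc2nc(C)cc(C)c2C(N)=O)CC1` gives 10 nM, compound 2 `COc1ccccc1N1CCN(CCCNc2cncnc2C(=O)N(C)C)CC1` gives 3.98 nM, and compound 3 `Cc1cnccc1N1CCN(CCCNc2ncccc2C(=O)N(C)C)CC1` gives 200 nM, the highest of the three numbers and therefore the weakest binder, separated from both others by more than the usual scatter.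

Compound 4 `COc1ccc(N2CCN(CCCNc3ncccc3C(=O)N(C)C)CC2)c(OC)c1` has not yet been measured. It differs from compound 3 in one place: 2,4-dimethoxyphenyl in place of 3-methylpyridin-4-yl on an amine nitrogen in a ring. Compounds 1 and 2, which carry a methoxyphenyl group on the same ring nitrogen, both sit far lower than compound 3, and compound 4 returns to an aryl group with methoxy substitution there.

For this reason compound 4 is expected to bind more tightly than compound 3, with an estimated step of a 13-fold lower number from compound 3 to compound 4 (1.12 log units; beyond the scatter) in this assay. The estimate for compound 4 is 15 nM, within a range from 4 nM to 60 nM, because compound 1 gives 10 nM and compound 2 gives 3.98 nM with related groups.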

Compound 4, dissociation constant: 31.6 nM
Estimate against measurement, compound 4: 2.1-fold (0.32 log units) below; measured number inside the range.
By their numbers in this assay, from the lowest: compound 2; then compound 1; then compound 4; then compound 3.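

In this assay, compound 3 and compound 4 differ only in the aryl group on the ring nitrogen, and placing 2,4-dimethoxyphenyl there instead of 3-methylpyridin-4-yl gives a 6.3-fold lower number from compound 3 to compound 4 (0.80 log units; beyond the scatter) on an otherwise unchanged structure. Going by these compounds alone, this shows that the group at this position can, on its own, shift the number beyond the usual scatter, something the other compounds could not show, as no other pair differs in only one place. No measurement here accounts for the size of this step.

The change replaces the ring, removes the methyl and adds both methoxy groups at once, so the contribution of each remains unresolved. An unsubstituted phenyl or a plain pyridin-4-yl at this position on the same core would help separate these contributions.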